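Methoxy in place of hydrogen: compound 2 to compound 3

The source may report more compounds than this note shows. Statements on the series, on what has been measured and on what is new or still open speak of the compounds shown alone.

Compound 2 `O=C(Nc1ccc(Oc2ccnc3[nH]ccc23)c(F)c1)c1cc2cccnc2n(-c2ccccc2)c1=O` gives 190 nM in a functional assay on A549 cells (Homo sapiens) for antiproliferative activity, read by MTT assay, with a stated time of 72 h; a lower number here means a stronger inhibitor, a higher number a weaker inhibitor. Among the compounds with values here, this is the lowest of the two numbers measured so far; the nearest is compound 1 `O=C(Nc1ccc(Oc2ccnc3[nH]ccc23)cc1)c1cc2cccnc2n(-c2ccccc2)c1=O`, which in this assay gives 360 nM. The step of a 1.9-fold lower number from compound 1 to compound 2 (0.28 log units; within the scatter), fluoro in place of hydrogen on an aromatic carbon, lies within the scatter, so no order between these two compounds is established.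

Compound 3 `COc1ccc(-n2c(=O)c(C(=O)Nc3ccc(Oc4ccnc5[nH]ccc45)c(F)c3)cc3cccnc32)cc1` differs from compound 2 by methoxy in place of hydrogen on an aromatic carbon of a six-membered aromatic ring of carbon only, para to a large group; cut one bond further out, the change reads phenyl to 4-methoxyphenyl. Within the data shown here, no measured step touches this ring or this group. Among the measured compounds shown here, the only step in hand, a 1.9-fold lower number from compound 1 to compound 2 (0.28 log units; within the scatter), concerns a different ring and stayed within the scatter, so it gives no direction for the present change. The expected step in this assay is no change at the digits printed from compound 2 to compound 3 (within the scatter), that is, nothing beyond the scatter and in no set direction. Compound 3 is estimated at 190 nM, with a range of 80 nM to 450 nM.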

Compound 3, half-maximal inhibitory concentration: 610 nM
Compound 3: the middle estimate sits 3.2-fold (0.51 log units) below what was measured; measured number outside the range, above it.
By their numbers in this assay, from the lowest: compounds 2, 1 and 3 (each within the scatter of the next, the first and the last beyond it).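

In this assay, within the data shown here, the step of a 3.2-fold higher number from compound 2 to compound 3 (0.51 log units; beyond the scatter) is the first reading from the ring that carries the new group, a six-membered aromatic ring of carbon only, and it shows that this ring is not indifferent to substitution: phenyl to 4-methoxyphenyl raises the number by a modest but readable amount. Among these compounds, the earlier step, a 1.9-fold lower number from compound 1 to compound 2 (0.28 log units; within the scatter), concerned a different ring and stayed within the scatter, so the methoxy change is the only step so far to lie beyond it. The direction at this place is therefore now set for one group only, with hydrogen giving the lower number and methoxy the higher; nothing at hand gives a measured basis for explaining this rise.

Still open, going by these compounds, is whether the rise belongs to methoxy itself or would also follow from another group at the same place, such as chloro, hydroxy, ethoxy or a dimethylamino group. Also open, on these data alone, is whether the step would hold on the core of compound 1, which has hydrogen in place of the fluoro of compound 2, and whether methoxy would read the same at other places on this ring.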